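Terphenyl-type hydroxyphenyl pyridines: cytotoxicity notes

The source may report more compounds than this note shows. Statements on the series, on what has been measured and on what is new or still open speak of the compounds shown alone.

Compound 1 `Oc1ccc(-c2cc(-c3ccccc3O)cc(-c3cccc(O)c3)n2)cc1` gives the highest number of the three measured compounds in an ADME assay on HEK293 cells (Homo sapiens) for cytotoxicity, read by CCK-8 assay, with a stated time of 4 days (on this read-out higher numbers stand for weaker inhibition and lower numbers for stronger inhibition), at 5650 nM. Compound 2 `Oc1ccc(-c2cc(-c3ccc(O)cc3)nc(-c3ccc(O)cc3)c2)cc1`, with three 4-hydroxyphenyl groups, gives 790 nM in this assay, and compound 3 `Oc1cccc(-c2cc(-c3ccccc3O)cc(-c3cccc(O)c3)n2)c1` gives 130 nM. Among the compounds with values here, the only step recorded from compound 1 is a 43-fold lower number from compound 1 to compound 3 (1.64 log units; beyond the scatter), a rearrangement of one hydroxyphenyl group on the shared core. Compound 4 `Oc1ccc(-c2cc(-c3cccc(O)c3)cc(-c3cccc(O)c3)n2)cc1` differs from compound 1 by 3-hydroxyphenyl in place of 2-hydroxyphenyl on an aromatic carbon, again a rearrangement of a single hydroxyphenyl group, but a different one, so the recorded step is only a loose guide. A lower number is expected for compound 4, likely a 7.1-fold lower number from compound 1 to compound 4 (0.85 log units; beyond the scatter), though smaller than the recorded step. Compound 4 is estimated at 800 nM in this assay, within 150 nM to 4000 nM.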

Compound 4, half-maximal inhibitory concentration: 1560 nM
For compound 4 the middle estimate is 2.0-fold (0.29 log units) below the measured one, and the stated range covers the measured number.
By their numbers in this assay, from the lowest: compound 3; then compounds 2 and 4 (each within the scatter of the next); then compound 1.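

The position opposite the ring nitrogen also responds to where the hydroxyl sits on its phenyl group: 3-hydroxyphenyl in place of 2-hydroxyphenyl gives a 3.6-fold lower number from compound 1 to compound 4 (0.56 log units; beyond the scatter) in this assay. This modest step is smaller than the large 43-fold lower number from compound 1 to compound 3 (1.64 log units; beyond the scatter) seen with the change at the 4-hydroxyphenyl group, so both places affect the number to different extents. Nothing available explains either step.

Still open, on these data alone, is how a methoxyphenyl or aminophenyl group would read opposite the ring nitrogen. Also open, as far as these compounds go, is whether the two single changes would add up in one compound.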